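Chloro in place of methoxy: a whole-animal comparison in mice

The compounds below may be only part of what the source reports. "The series", "measured", "known", "first", "only" and "open" are said of these compounds alone.

Measured so far:
Compound 1, `COc1ccccc1/C=C/C(=O)OC/C=C/c1cc(OC)c(OC)cc1OC`, gives 100%
Compound 2, `COc1cc(OC)c(OC)cc1/C=C/COC(=O)/C=C/c1ccccc1Cl`, gives 100%
Compound 3, `COc1ccc(/C=C/C(=O)OC/C=C/c2cc(OC)c(OC)cc2OC)cc1`, gives 100%

All three values come from a functional assay on the whole organism (strain Kunming) with Mus musculus as the target, with a stated time of 0.5 h, at a dose of 100 mg/kg by the intraperitoneal route; a lower number here means a stronger effect, a higher number a weaker effect of the compound at the dose given. Compound 1 and compound 2 share a core and differ in one place: chloro in place of methoxy on an aromatic carbon. That change moved the read-out by no change at the digits printed from compound 1 to compound 2 (within the scatter). Compound 3 carries the same atoms as compound 1 joined differently, and the difference between the two cores is 4-methoxyphenyl in place of 2-methoxyphenyl on a double-bonded chain carbon bound to a double-bonded chain carbon; the step of no change at the digits printed from compound 1 to compound 3 (within the scatter) shows no movement either. Compound 2 and compound 3 also stand level, as no change at the digits printed from compound 2 to compound 3 (within the scatter) shows.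

Compound 4, `COc1cc(OC)c(OC)cc1/C=C/COC(=O)/C=C/c1ccc(Cl)cc1`, has not yet been measured. It differs from compound 3 by chloro in place of methoxy on an aromatic carbon. Within the data shown here, this is the same kind of change as the one from compound 1 to compound 2, though not the same: there the chloro sat ortho to a large group, here it sits para to a large group.

Because no change at the digits printed from compound 1 to compound 2 (within the scatter) stayed within the scatter, and because compound 3 gives 100%, level with the other two, the step to compound 4 is expected to be no change at the digits printed from compound 3 to compound 4 (within the scatter). For compound 4 the estimated result in this assay is 100%, with an expected range from 85% to 100%. This rests on three measured compounds only, and a fourth could still break the pattern.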

Compound 4, a percentage reported as activity, at one dose (the size of the read-out at that dose, not a potency): 100%
Beside the measured number, compound 4's estimate shows no gap at the digits printed; low and high end bracket the measured number.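

Carrying chloro in place of methoxy from one core to the other gave the same outcome in this assay, with no change at the digits printed from compound 3 to compound 4 (within the scatter) matching the earlier step on the other core: the same change on two cores in this assay, no change at the digits printed (within the scatter) from compound 1 to compound 2 and no change at the digits printed (within the scatter) from compound 3 to compound 4, 0 percentage points apart, within the scatter of two such steps

The two remaining new steps agree with this, since no change at the digits printed from compound 2 to compound 4 (within the scatter) and no change at the digits printed from compound 1 to compound 4 (within the scatter) also show no movement when 4-chlorophenyl replaces 2-chlorophenyl or 2-methoxyphenyl. What this shows is limited: on these two cores, at this one dose, the change leaves the read-out where it was, but it does not show that the change would be silent on any other core, and it gives no measure of potency, as a single-dose read-out that is level across all four compounds cannot rank them.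

The compounds shown leave open what an amine or a carboxylic acid on the aromatic ring, in place of chloro or methoxy, would do to the read-out. They also leave open whether these four compounds would still stand level at a lower dose, where a difference between them might appear.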